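Phenoxy in place of trifluoromethoxy on a triazole scaffold

The compounds below may be only part of what the source reports. "The series", "measured", "known", "first", "only" and "open" are said of these compounds alone.

Measured compounds:
compound 1 `COc1ccc(-c2cn(-c3ccc(OC(F)(F)F)cc3)nn2)cc1O`: > 10000 nM
compound 2 `COc1ccc(-n2cc(-c3ccc(OC)c(OC)c3)nn2)c(OC)c1`: "not determined" (no result reported)
compound 3 `Nc1ccc(-c2cn(-c3ccc(OC(F)(F)F)cc3)nn2)cc1`: > 10 nM

In a functional assay on MDA-MB-231 cells (Homo sapiens) for cytotoxicity, read by MTT assay (on this read-out higher numbers stand for weaker inhibition and lower numbers for stronger inhibition), compound 1 gives > 10000 nM, which is a limit of the assay and not a number. For compound 2 the outcome in this assay is "not determined" (no result reported), so no value exists for it. Compound 3 gives > 10 nM, again a limit rather than a number. Compound 1 therefore stands at a limit; one of the other two values is also a limit (the limit of > 10 nM in this assay, at which 1 of the 3 values shown sits), and the remaining entry carries no number at all (the limit of > 10000 nM in this assay, at which 1 of the 3 values shown sits). Going by the values given here, no step between two measured compounds can be given.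

The unmeasured compound 4 `COc1ccc(-c2cn(-c3ccc(Oc4ccccc4)cc3)nn2)cc1O` differs from compound 1 in one place: phenyl in place of trifluoromethyl on an oxygen on an aromatic ring. Because compound 1 sits at > 10000 nM, only a limit, nothing measured here marks a direction for this change. Compound 4 is expected to give 10000 nM, estimated to lie between 3000 nM and 30000 nM. The expected shift is a number no higher from compound 1 to compound 4 (the limit leaves the size open), that is, no change beyond the scatter, with a real chance that only a limit is reported again.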

Compound 4, half-maximal inhibitory concentration: > 10000 nM
Compound 4: only a limit was reported (the forecaster's own chance of this, stated with the estimate: 60%); the middle value sits exactly at the limit.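

Compound 1 and compound 4 each carry only a limit and not a number, so no step can be read for the change from trifluoromethoxy to phenoxy. The compounds shown leave open what either compound's actual value is, and whether this change shifts the cytotoxicity read-out at all.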